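Phenol-to-lactam exchange on the urea aryl group

A few compounds are considered here, and "the series" means these few. Any claim that something is new, unique, unknown or untested is made for them only; others in the source may bear on it.

Two compounds of this series carry the same core and urea linkage and have been read in an assay on CHO cells for antagonist activity at transient receptor potential cation channel subfamily V member 1 (Homo sapiens), read by scintillation counting, with a stated time of 5 min, in the presence of a further agent that is not named here; a lower number here means that less compound is needed, a higher number that more compound is needed for the effect. Compound 1 `CN(C)C1(Cc2ccccc2)CCN(c2cc(C(F)(F)F)ccc2CNC(=O)NCc2ccc(NS(C)(=O)=O)c(F)c2)CC1` gives 85.9 nM. Compound 2 `CN(C)C1(Cc2ccccc2)CCN(c2cc(C(F)(F)F)ccc2CNC(=O)Nc2cccc3ccc(O)cc23)CC1` gives 8.9 nM; of the two numbers this is the lower, and the gap to compound 1 lies beyond the usual scatter, so compound 2 stands as the more potent of the pair on this assay.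

Compound 3 `CN(C)C1(Cc2ccccc2)CCN(c2cc(C(F)(F)F)ccc2CNC(=O)Nc2cccc3c(=O)[nH]ccc23)CC1` is the next member to be measured. Its change relative to compound 2 is a group of 11 heavy atoms (9 carbon, 1 nitrogen, 1 oxygen; one six-membered aromatic ring of carbon only, one six-membered aromatic ring with 1 hetero atom) in place of a group of 11 heavy atoms (10 carbon, 1 oxygen; 2 six-membered aromatic rings of carbon only), on an amide-type nitrogen. The 7-hydroxynaphthalen-1-yl group leaves and the entering group keeps one hydrogen-bond donor and one acceptor in a bicyclic frame of equal size. Within the data shown here, no measured pair in the set shows this kind of exchange, so nothing here fixes its effect. The expectation is a small step, if any, most likely a slight rise in the number and within or just at the edge of scatter, as a 1.7-fold higher number from compound 2 to compound 3 (0.23 log units; within the scatter). Compound 3 is estimated at 15 nM, with a range from 4 nM to 60 nM.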

Compound 3, half-maximal effective concentration: "not active" (no number reported)
The entry for compound 3 holds no number; there is nothing to compare the estimate with.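

Among these compounds, compound 3 is recorded in this assay as "not active" without a number, so no step from compound 2 to compound 3 can be read. Nothing available bears on this result. The compounds shown leave open how large the effect of this exchange on the urea nitrogen is.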